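The source may hold more compounds than are shown below. What is called first, only, known or untested is meant among the compounds shown, and "the series" means these compounds.

Measured so far:
compound 1 `CC(C)[C@H](C(=O)NC(C)(C)C)c1ccc(Cl)cc1` — < 30%, a limit of the assay
compound 2 `CC(C)C(C(=O)Nc1ncccn1)c1ccc(Cl)cc1` — 50%

In a functional assay on CHO cells for agonist activity at Free fatty acid receptor 2 (Homo sapiens), read by cAMP accumulation (a higher number here means a larger maximal response, a lower number a smaller maximal response), compound 1 stands only at a limit, (the limit of < 30% in this assay, at which 1 of the 2 values shown sits), with no number of its own. Compound 2 gives 50% in this assay. Compound 3 `CC(C)[C@H](C(=O)Nc1cccnn1)c1ccc(Cl)cc1` differs from compound 1 by pyridazin-3-yl in place of tert-butyl on an amide-type nitrogen. For the measured compounds named here, no measured pair shares this change, so the size of the step is open. The step of a number at least 15 percentage points higher from compound 1 to compound 3 (beyond the scatter) is expected to run upward, beyond the usual scatter, since compound 2, also carrying a six-membered aromatic ring on the amide nitrogen, reaches 50%. Compound 3 is estimated at 45%, from 20% to 70%.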

Compound 3, largest response reached (reported as efficacy), in percent of the reference or control that the assay uses: 101%
Estimate against measurement, compound 3: 56 percentage points below; the measured number lies above the stated range.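

For the compounds shown here, at the amide-type nitrogen, the earlier compounds left the size of any change open; in this assay, pyridazin-3-yl in place of tert-butyl gives a number at least 71 percentage points higher from compound 1 to compound 3 (beyond the scatter). Compound 3 gives 101%, so this six-membered aromatic ring at this place supports a large maximal response. Compound 1 carries a limit of the assay, which makes the step a floor on the true size: the limit of < 30% in this assay, at which 1 of the 3 values shown sits.

Whether the ring's two nitrogens matter stays open, since a plain phenyl on the amide nitrogen is not among the compounds shown. Also open, on these data alone, is how an amine or a carboxylic acid on the pyridazin-3-yl ring would change the response.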